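The source may report more compounds than this note shows. Statements on the series, on what has been measured and on what is new or still open speak of the compounds shown alone.

Compound 1 `C[C@@H](NC(=O)[C@H](CCCNC(=N)N)NC(=O)c1ccc(CN(Cc2ccc(F)cc2)Cc2ccccn2)cc1)c1cccc2ccccc12`: 35000 nM
Compound 2 `C[C@@H](NC(=O)[C@H](CCCNC(=N)N)NC(=O)c1ccc(CN(Cc2ccccn2)C(=O)c2ccc(F)cc2)cc1)c1cccc2ccccc12`: 38000 nM
Compound 3 `C[C@H](NC(=O)[C@H](CCCNC(=N)N)NC(=O)c1ccc(CN(Cc2ccc(F)cc2)Cc2ccccn2)cc1)c1cccc2ccccc12`: 11000 nM

In an ADME assay on MT4 cells (Homo sapiens) for cytotoxicity (on this read-out higher numbers stand for lower toxicity in this test and lower numbers for higher toxicity in this test), compound 3 stands lowest of the three at 11000 nM. Compound 4 `C[C@H](NC(=O)[C@H](CCCNC(=N)N)NC(=O)c1ccc(CN(Cc2ccncc2)Cc2ccc(F)cc2)cc1)c1cccc2ccccc12` has pyridin-4-yl in place of pyridin-2-yl on a saturated chain carbon bound to an amine nitrogen. Within the data shown here, no measured step makes this swap, so the evidence is indirect. Replacing 4-fluorobenzyl with (4-fluorophenyl)carbonyl on an amine nitrogen gave a 1.1-fold higher number from compound 1 to compound 2 (0.04 log units; within the scatter), while changing a stereocentre from R to S gave a 3.2-fold lower number from compound 1 to compound 3 (0.50 log units; beyond the scatter). The first step, within the scatter, suggests that this part of the molecule can tolerate change, so the expected size is a 1.2-fold higher number from compound 3 to compound 4 (0.07 log units; within the scatter), no step beyond the scatter. For compound 4 the estimated value is 13000 nM, with an expected range from 5500 nM to 30000 nM.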

Compound 4, half-maximal cytotoxic concentration: 44000 nM
Compound 4: middle estimate off by 3.4-fold (0.53 log units), on the low side, and the stated range ends below it.
By their numbers in this assay, from the lowest: compound 3; then compounds 1, 2 and 4 (each within the scatter of the next).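

Replacing pyridin-2-yl with pyridin-4-yl on a saturated chain carbon bound to an amine nitrogen gave a 4.0-fold higher number from compound 3 to compound 4 (0.60 log units; beyond the scatter) in this assay. Among these compounds, the two groups have the same atoms, joined differently, so this read-out responds to that rearrangement alone, at a place the earlier compounds left unchanged. No measurement shown explains this shift.

Still open, on these data alone, is how a pyridin-3-yl or plain phenyl group would read at this place. Also open, as far as these compounds go, is whether the same swap would give a similar step on the R form, compound 1.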